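Swapping Methoxy for Nitro on a Shared Core

The source may report more compounds than this note shows. Statements on the series, on what has been measured and on what is new or still open speak of the compounds shown alone.

Of the compounds shown here, two built on the same core have been measured so far. Compound 1 `O=C1CSC(c2cccc(O)c2)N1CCN1CCCCC1` carries a hydroxy-bearing aromatic ring, and compound 2 `COc1ccccc1C1SCC(=O)N1CCN1CCCCC1` carries a methoxy group on its aromatic ring instead. In an ADME assay on Vero cells (Chlorocebus sabaeus) for cytotoxicity, read by neutral red uptake, tested at 12.3 ug/mL (a lower number here means a stronger effect, a higher number a weaker effect of the compound at the concentration tested), compound 1 gives 100%. In this assay compound 2 gives 100%, which is level with compound 1 at the digits shown and lies within the usual scatter of such measurements, so neither compound can be said to differ from the other here.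

Compound 3 `O=C1CSC(c2ccccc2[N+](=O)[O-])N1CCN1CCCCC1` is the next compound to be tested and has not yet been measured. It differs from compound 2 in a single place: nitro in place of methoxy on an aromatic carbon. Among the compounds with values here, nothing among the measured compounds shows a change in this assay, so there is no measured step to lean on. On the evidence available, the step of no change at the digits printed from compound 2 to compound 3 (within the scatter) is expected to be none beyond the scatter. Compound 3 is therefore expected to give 100%, with a plausible range from 88% to 108%.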

Compound 3, a percentage reported as activity, at one concentration (the size of the read-out at that concentration, not a potency): 100%
Compound 3: middle estimate and measured number agree at the digits printed; the range from low to high includes it.
By their numbers in this assay, from the lowest: compounds 1, 2 and 3 (each within the scatter of the next).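

In this assay, nitro in place of methoxy on an aromatic carbon, ortho to a large group, gives no change at the digits printed from compound 2 to compound 3 (within the scatter) and is the first step shown between two compounds that differ in one place. This position on the six-membered aromatic ring therefore now has a measured comparison: the two groups differ in their atoms, and nitro also brings a double bond outside aromatic rings, yet the read-out at this single concentration stays level. The measurements shown offer no explanation for this result.

The compounds shown leave open what an amine, a carboxylic acid or a longer chain on this same aromatic carbon would do in this assay. They also leave open whether any change to the shared core can lower the number at all, as all three compounds stand level at the one concentration tested.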